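The source may report more compounds than this note shows. Statements on the series, on what has been measured and on what is new or still open speak of the compounds shown alone.

Measured so far in an ADME assay on HEK293 cells (Homo sapiens) for cytotoxicity, read by sulforhodamine B assay, with a stated time of 48 h, tested at 10 uM; on this read-out higher numbers stand for more inhibition at the one concentration tested (going by the name of the read-out) and lower numbers for less inhibition:

- compound 1 `COc1nc2ccc(Br)cc2cc1C(c1ccccc1)n1cc(-c2ccc(Br)cc2)nn1`: 6.28%
- compound 2 `CCCCCCCc1cn(C(c2ccccc2)c2cc3cc(Br)ccc3nc2OC)nn1`: 0.17%

Compound 2 stands lowest of the two numbers in this assay; its nearest neighbour is compound 1, with a gap of a number 6.1 percentage points lower from compound 1 to compound 2 (within the scatter), which lies within the scatter. Both compounds share the same core and differ only in the group on the aromatic carbon of the triazole, heptyl in compound 2 against 4-bromophenyl in compound 1.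

Compound 3 `CCCCCCc1cn(C(c2ccccc2)c2cc3cc(Br)ccc3nc2OC)nn1` is not yet measured. It differs from compound 2 by hydrogen in place of methyl on a saturated chain carbon, six bonds along the chain from an aromatic carbon. Among the compounds with values here, the only measured step, a number 6.1 percentage points lower from compound 1 to compound 2 (within the scatter), swaps a whole aromatic group for the heptyl chain and still stays within the scatter. Within the data shown here, no measured pair shortens the chain by one carbon, so nothing in the data points to a shift beyond the scatter for a change as small as this one.

The expectation for compound 3 in this assay is therefore a value close to that of compound 2, and a step of a number 1.3 percentage points higher from compound 2 to compound 3 (within the scatter) is expected rather than any change beyond the scatter. The estimate for compound 3 is 1.5%, with a range from 0% to 9%.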

Compound 3, a percentage reported as inhibition, at one concentration (the size of the read-out at that concentration, not a potency): -3.17%
Compound 3: the middle estimate sits 4.7 percentage points above what was measured; the whole stated range lies above it.
By their numbers in this assay, from the lowest: compounds 3, 2 and 1 (each within the scatter of the next).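

In this assay, the step from heptyl to hexyl, hydrogen in place of methyl on a saturated chain carbon, six bonds along the chain from an aromatic carbon, reads a number 3.3 percentage points lower from compound 2 to compound 3 (within the scatter), so this trimming of the chain end leaves the read-out within the scatter. The swap of the 4-bromophenyl group for a hexyl chain reads a number 9.5 percentage points lower from compound 1 to compound 3 (within the scatter), so a second chain length now also stands within the scatter of the 4-bromophenyl compound, and none of the three groups at this site separates from the others in this assay. No supporting measurement bears on these numbers, and they stand here without any explanation.

On these data alone, whether a much shorter chain such as methyl or butyl, a longer chain such as dodecyl, or a chain ending in an amine or a carboxylic acid would move the read-out beyond the scatter remains open. Also open, as far as these compounds go, is how these compounds would read at other concentrations, since the values shown come from a single concentration and cover changes at this one site on the shared core.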